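The source may report more compounds than this note shows. Statements on the series, on what has been measured and on what is new or still open speak of the compounds shown alone.

In a physicochemical assay for lipophilicity (on this read-out higher numbers stand for higher lipophilicity and lower numbers for lower lipophilicity), three esters sharing one core have been measured. Compound 1 (`C/C=C/C=C/C(=O)OCC`) gives (1.84), compound 2 (`C/C=C/C=C/C(=O)OCCC`) gives (2.31) and compound 3 (`C/C=C/C=C/C(=O)OCCCC`) gives (2.71). Compound 3 therefore stands highest of the three. Lengthening the chain produced modest rises, first (a number 0.47 log units higher from compound 1 to compound 2 (beyond the scatter)) and then (a number 0.40 log units higher from compound 2 to compound 3 (beyond the scatter)), which add up to (a number 0.87 log units higher from compound 1 to compound 3 (beyond the scatter)).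

Compound 4 (`C/C=C/C=C/C(=O)OC(C)(C)C`) has not been measured yet. It carries tert-butyl in place of butyl on an oxygen next to a carbonyl group. Every measured step lengthens the chain, whereas this change keeps the same atoms, joined differently, and no branched ester has been measured. The last lengthening (a number 0.40 log units higher from compound 2 to compound 3 (beyond the scatter)) is the closest guide. The tert-butyl group contains no chain that long, so a small drop is expected, smaller than that step and perhaps not beyond the usual scatter. The expected change is (a number 0.21 log units lower from compound 3 to compound 4 (within the scatter)). Compound 4 is estimated at (2.5), with an expected range from (2.15) to (2.8).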

Compound 4, partition coefficient: 2.33
Compound 4: the middle estimate sits 0.17 log units above what was measured; low and high end bracket the measured number.
By their numbers in this assay, from the lowest: compound 1; then compounds 2 and 4 (each within the scatter of the next); then compound 3.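

Until now only chain length had varied on an oxygen next to a carbonyl group; here the atoms stay the same and only the way they are joined changes, yet swapping butyl for tert-butyl still shifts the number in this assay (a number 0.38 log units lower from compound 3 to compound 4 (beyond the scatter)). The tert-butyl ester lies within the scatter of the propyl ester (a number 0.02 log units higher from compound 2 to compound 4 (within the scatter)) but remains clearly apart from the ethyl ester (a number 0.49 log units higher from compound 1 to compound 4 (beyond the scatter)), so among these compounds the carbon count alone does not set the read-out, with compound 4 going against the trend of the straight chains. Nothing available explains this shift.

Among these compounds, with tert-butyl as the only branched group here, it remains open whether isopropyl or isobutyl would follow the same pattern. As far as these compounds go, how a cyclohexyl ring or a chain carrying a hydroxyl group would compare on this oxygen also remains open.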